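A few compounds are considered here, and "the series" means these few. Any claim that something is new, unique, unknown or untested is made for them only; others in the source may bear on it.

Three compounds share one core. In a functional assay on DLD-1 cells (Homo sapiens) for cytotoxicity, with a stated time of 48 h (a higher number here means a weaker inhibitor, a lower number a stronger inhibitor), compound 1 `COc1ccc2c(=O)cc(/C=C/[S+](C)[O-])oc2c1` gives 7800 nM, compound 3 `Cc1ccc2c(=O)cc(/C=C/[S+](C)[O-])oc2c1` gives 7000 nM, and compound 2 `C[S+]([O-])/C=C/c1cc(=O)c2cc(Cl)ccc2o1` gives 6500 nM, a number separated from those of compound 3 and compound 1 only within the scatter. Among the compounds with values here, the single one-place step among them, a 1.1-fold lower number from compound 1 to compound 3 (0.05 log units; within the scatter), shows a change on that aromatic carbon leaving the read-out essentially where it was. Compound 4 `C[S+]([O-])/C=C/c1cc(=O)c2cc(O)ccc2o1` differs from compound 2 by hydroxy in place of chloro on an aromatic carbon. Within the data shown here, this is a change of the same kind, at the same aromatic carbon, so no shift beyond the scatter is expected in this assay because the one comparable step a 1.1-fold lower number from compound 1 to compound 3 (0.05 log units; within the scatter) lay within the scatter. Compound 4 is therefore estimated at 7000 nM, between 3000 nM and 16000 nM, which means an expected step of a 1.1-fold higher number from compound 2 to compound 4 (0.03 log units; within the scatter).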

Compound 4, half-maximal inhibitory concentration: > 10000 nM
Compound 4 was reported as a limit; the forecaster's own chance of this, stated with the estimate: 5%; middle value at least 1.4-fold (0.15 log units) away from the limit.
By their numbers in this assay, from the lowest: compounds 2, 3 and 1 (each within the scatter of the next). At a limit, above all of these: compound 4.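

In this assay compound 4 gives > 10000 nM, which is a limit and not a number. Hydroxy in place of chloro is thus the only change on an aromatic carbon here that ends at a limit, and the step is open on one side: an at least 1.5-fold higher number from compound 2 to compound 4 (0.18 log units; that floor lies within the scatter). The true size of this step may therefore lie within the scatter or well beyond it, which the earlier step, with a number at both ends, did not leave undecided. The compounds shown leave open where hydroxy would fall on a measured scale, and how an amine or a carboxylic acid on this aromatic carbon would read.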